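This account rests on a few compounds, and the source may have more. Where it says the series, first, only, none or still open, it means among the compounds named here.

Among the measured compounds shown here, compound 2 `Fc1ccc(C2=NN(C3=NC(c4ccccc4)CS3)C(c3cccc4ccccc34)C2)cc1` gives the highest number of the two values so far in a functional assay on HepG2 cells (Homo sapiens) for inhibition, read by CCK-8 assay, with a stated time of 48 h (a lower number here means a stronger inhibitor, a higher number a weaker inhibitor), at 23200 nM. For the measured compounds named here, its only neighbour is compound 1 `COc1ccc(C2=NN(C3=NC(c4ccccc4)CS3)C(c3cccc4ccccc34)C2)cc1`, which in this assay gives 8740 nM; the step of a 2.7-fold higher number from compound 1 to compound 2 (0.42 log units; beyond the scatter) is a modest one, with fluoro in place of methoxy on an aromatic carbon. Compound 3 `Cc1ccc(C2=NN(C3=NC(c4ccccc4)CS3)C(c3cccc4ccccc34)C2)cc1C` differs from compound 2 by 3,4-dimethylphenyl in place of 4-fluorophenyl on a carbon with a double bond to nitrogen. Going by the values given here, no measured step matches this change directly; the one step that bears on it shows that swapping the group on that aryl ring moves the number by a modest amount in either direction. The expectation is therefore a modest step back toward the lower number, a 1.9-fold lower number from compound 2 to compound 3 (0.29 log units; within the scatter), with the range kept wide since nothing measured covers the dimethyl substitution. Compound 3 is estimated at 12000 nM in this assay, between 4000 nM and 36000 nM.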

Compound 3, half-maximal inhibitory concentration: 7250 nM
Estimate against measurement, compound 3: 1.7-fold (0.22 log units) above; the measured number falls inside the stated range.
By their numbers in this assay, from the lowest: compounds 3 and 1 (each within the scatter of the next); then compound 2.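

At this place on the shared core, 3,4-dimethylphenyl in place of 4-fluorophenyl gives a 3.2-fold lower number from compound 2 to compound 3 (0.51 log units; beyond the scatter) in this assay, so the earlier step from the fluoro compound is no longer the only one of its kind. Against 4-methoxyphenyl, the same group gives a 1.2-fold lower number from compound 1 to compound 3 (0.08 log units; within the scatter), which means that these two differently substituted aryl rings cannot be told apart in this read-out, and 4-fluorophenyl alone stands apart from both. Nothing at hand explains these differences.

The compounds shown leave open how an aryl ring carrying an amine or a carboxylic acid would read at this place, and whether a single methyl group would match the two in compound 3. From the compounds shown here alone, the naphthalen-1-yl group and the phenyl group stay the same throughout, so their contribution remains untested here.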